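The source may hold more compounds than are shown below. What is called first, only, known or untested is meant among the compounds shown, and "the series" means these compounds.

Measured in a functional assay on HeLa cells (Homo sapiens) for inhibition, with a stated time of 72 h (on this read-out lower numbers stand for an effect already at smaller amounts and higher numbers for an effect only at larger amounts of compound), so far:
- compound 1 `COc1cc(CNCc2ccccc2)ccc1OCc1ccc(Cl)nc1` gives 90000 nM
- compound 2 `Clc1ccc(COc2ccc(CNCc3ccncc3)cc2)cc1` gives 4000 nM
- compound 3 `COc1cc(CNCc2ccncc2)ccc1OCc1ccc(Cl)c(Cl)c1` gives 4000 nM

Compound 3 stands level with compound 2, and both sit well under compound 1, a gap beyond the usual scatter. Compound 4 `COc1cc(CNCc2ccncc2)ccc1OCc1ccc(Cl)nc1` carries 6-chloropyridin-3-yl in place of 3,4-dichlorophenyl on a saturated chain carbon bound to an oxygen on an aromatic ring. Among the measured compounds shown here, no measured pair isolates this change. For the measured compounds named here, the only guide is compound 1 (90000 nM), which also carries 6-chloropyridin-3-yl. A moderate move toward a higher number is therefore expected, probably beyond the scatter, and the expected size is a 3.5-fold higher number from compound 3 to compound 4 (0.54 log units; beyond the scatter) in this assay on this estimate. For compound 4 the estimated value is 14000 nM, with an expected range from 3000 nM to 60000 nM in this assay.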

Compound 4, half-maximal effective concentration: 400 nM
Beside the measured number, compound 4's estimate is 35-fold (1.54 log units) above it; the whole stated range lies above it.
By their numbers in this assay, from the lowest: compound 4; then compounds 2 and 3 (each within the scatter of the next); then compound 1.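

In this assay, 6-chloropyridin-3-yl in place of 3,4-dichlorophenyl on a saturated chain carbon bound to an oxygen on an aromatic ring gives a 10-fold lower number from compound 3 to compound 4 (1.00 log units; beyond the scatter), so this group is no drawback here once pyridin-4-yl is present. The high number of compound 1 instead goes with its phenyl, as pyridin-4-yl in place of phenyl on a saturated chain carbon bound to an amine nitrogen gives a 230-fold lower number from compound 1 to compound 4 (2.35 log units; beyond the scatter). Nothing at hand explains either step.

The compounds shown leave open whether 6-fluoropyridin-3-yl or 6-methoxypyridin-3-yl would hold the lower number. They also leave open how pyridin-3-yl would compare with pyridin-4-yl on the amine side.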